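The compounds below may be only part of what the source reports. "The series", "measured", "known", "first", "only" and "open" are said of these compounds alone.

In an assay for inhibition of 6-phosphofructo-2-kinase/fructose-2,6-bisphosphatase 3 (Homo sapiens), read by ADP-Glo, with a stated time of 2 h (on this read-out lower numbers stand for stronger inhibition and higher numbers for weaker inhibition), compound 1 `CN1CCC(CNS(=O)(=O)c2ccccc2Nc2cc(-c3ccc4ccn(C)c4c3)c3nccnc3c2)C1` gives 11 nM, compound 2 `Cn1ccc2ccc(-c3cc(Nc4ccccc4S(N)(=O)=O)cc4nccnc34)cc21` gives 265 nM, and compound 3 `CNS(=O)(=O)c1ccccc1Nc1cc(-c2ccc3ccn(C)c3c2)c2nccnc2c1` gives 104 nM. Compound 3 thus holds the second highest of the three numbers, closest to compound 2 and furthest from compound 1. Compound 4 `CN(C)S(=O)(=O)c1ccccc1Nc1cc(-c2ccc3ccn(C)c3c2)c2nccnc2c1` carries the change (methyl in place of hydrogen on a sulfonamide nitrogen). Among the measured compounds shown here, two measured steps bear on it: a 2.5-fold lower number from compound 2 to compound 3 (0.41 log units; beyond the scatter), the same exchange at the same nitrogen, and a 9.5-fold higher number from compound 1 to compound 3 (0.98 log units; beyond the scatter), which points the same way. A modest lowering is therefore expected, though a second methyl need not repeat what the first one did. Compound 4 is estimated at 55 nM, with a range of 20 nM to 160 nM. The expected step is then a 1.9-fold lower number from compound 3 to compound 4 (0.28 log units; within the scatter).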

Compound 4, half-maximal inhibitory concentration in the 6-phosphofructo-2-kinase/fructose-2,6-bisphosphatase 3 assay: 94 nM
Beside the measured number, compound 4's estimate is 1.7-fold (0.23 log units) below it; the measured number falls inside the stated range.
By their numbers in the 6-phosphofructo-2-kinase/fructose-2,6-bisphosphatase 3 assay, from the lowest: compound 1; then compounds 4 and 3 (each within the scatter of the next); then compound 2.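

In the 6-phosphofructo-2-kinase/fructose-2,6-bisphosphatase 3 assay the first methyl on the sulfonamide nitrogen brings a 2.5-fold lower number from compound 2 to compound 3 (0.41 log units; beyond the scatter), the second methyl brings a 1.1-fold lower number from compound 3 to compound 4 (0.04 log units; within the scatter) and the full exchange of amino for dimethylamino brings a 2.8-fold lower number from compound 2 to compound 4 (0.45 log units; beyond the scatter), so what this nitrogen gains from methyl comes with the first one. Dimethylamino does not close the gap to the larger substituent of compound 1, with an 8.5-fold higher number from compound 1 to compound 4 (0.93 log units; beyond the scatter) still standing in the 6-phosphofructo-2-kinase/fructose-2,6-bisphosphatase 3 assay. In a physicochemical assay for solubility, read by spectrophotometry, measured as kinetic solubility, at pH 8, tested at 500 uM (a higher number here means a more soluble compound, a lower number a less soluble compound), compound 3 gives 2 ug/mL and compound 4 gives 2 ug/mL. In the physicochemical assay the same change shows no change at the digits printed from compound 3 to compound 4 (within the scatter).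

On these data alone, whether compound 1 owes its number to the amine of its side chain or to the length of that chain stays open, and a longer chain without an amine, or with a carboxylic acid in its place, would separate the two. No evidence given here accounts for any of these steps.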